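Changing the Aryl Group on the Ring Nitrogen

A few compounds are considered here, and "the series" means these few. Any claim that something is new, unique, unknown or untested is made for them only; others in the source may bear on it.

Of the compounds shown here, three that share one core have been measured in a functional assay for antagonist activity at transient receptor potential cation channel subfamily V member 1 (Homo sapiens), read by FLIPR and calcium flux; on this read-out lower numbers stand for stronger inhibition and higher numbers for weaker inhibition. Compound 1 `Cc1cccc(N2CCC(C(=O)Nc3ccc4c(c3)NC(=O)CO4)CC2)c1` gives 490 nM, compound 2 `CC(C)c1ccccc1N1CCC(C(=O)Nc2ccc3c(c2)NC(=O)CO3)CC1` gives 180 nM, and compound 3 `O=C1COc2ccc(NC(=O)C3CCN(c4cc(F)c(F)c(F)c4)CC3)cc2N1` gives 59 nM. Compound 3 stands lowest of the three: the step of an 8.3-fold lower number from compound 1 to compound 3 (0.92 log units; beyond the scatter) and the step of a 3.1-fold lower number from compound 2 to compound 3 (0.48 log units; beyond the scatter) both lie beyond the scatter, so compound 3 is the strongest inhibitor measured so far. The step of a 2.7-fold lower number from compound 1 to compound 2 (0.43 log units; beyond the scatter) shows that exchanging one substituted phenyl group for another already moves the number.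

Compound 4 `O=C1COc2ccc(NC(=O)C3CCN(c4ccccc4Cl)CC3)cc2N1` has not yet been measured. It differs from compound 3 in one place: 2-chlorophenyl in place of 3,4,5-trifluorophenyl on an amine nitrogen in a ring. The three measured steps all change the group on this same ring nitrogen, and both phenyl groups with a single substituent gave higher numbers than the trifluorophenyl group. Compound 2, which carries 2-isopropylphenyl, gave 180 nM. Because compound 3 gave 59 nM and the step of a 3.1-fold lower number from compound 2 to compound 3 (0.48 log units; beyond the scatter) was modest, a modest rise of similar size is expected for compound 4, namely a 2.5-fold higher number from compound 3 to compound 4 (0.41 log units; beyond the scatter). Compound 4 is therefore estimated at 150 nM, with a range from 50 nM to 450 nM.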

Compound 4, half-maximal inhibitory concentration: 220 nM
The estimate for compound 4 lay 1.5-fold (0.17 log units) below the measured number; the range from low to high includes it.
By their numbers in this assay, from the lowest: compound 3; then compounds 2 and 4 (each within the scatter of the next); then compound 1.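

Exchanging the 3,4,5-trifluorophenyl group on the ring nitrogen for 2-chlorophenyl gives a 3.7-fold higher number from compound 3 to compound 4 (0.57 log units; beyond the scatter) in this assay and thus leaves compound 3 as the strongest inhibitor shown, while exchanging isopropyl for chloro on the aromatic carbon gives a 1.2-fold higher number from compound 2 to compound 4 (0.09 log units; within the scatter) and so does not separate these two groups on this read-out. Replacing 3-methylphenyl with 2-chlorophenyl gives a 2.2-fold lower number from compound 1 to compound 4 (0.35 log units; beyond the scatter) here, which places both compounds with a group at the 2 position of the phenyl ring, compound 2 and compound 4, under compound 1, although compound 3, with no such group, goes against any simple preference for that arrangement, and this step changes both the substituent and its place on the phenyl ring. Nothing available here explains these differences in number and the measured values alone must carry the comparison.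

The compounds shown leave open how a phenyl group with no substituent would compare, and whether one or two fluorine atoms would give a number closer to that of compound 3 or of compound 4. They also leave open what a phenyl ring bearing an amine or a carboxylic acid would do on this same ring nitrogen.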